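Swapping Methoxy for Methyl in Compound 2

This account rests on a few compounds, and the source may have more. Where it says the series, first, only, none or still open, it means among the compounds named here.

In an ADME assay for pharmacokinetics, at pH 7.4 (a higher number here means that the compound lasts longer, a lower number that the compound disappears faster), compound 1 `COc1cnc(C[S+]([O-])c2nc3cc(OC(F)F)ccc3[nH]2)cc1OC` gives > 200 h, which is a limit of the assay and not a number. Among the measured compounds shown here, compound 2 `COc1cnc(C[S+]([O-])c2nc3cc(OC(F)F)ccc3[nH]2)c(C)c1OC` gives 60 h, the only true number so far. Compound 3 `COc1c(C)cnc(C[S+]([O-])c2nc3cc(OC(F)F)ccc3[nH]2)c1C` differs from it by methyl in place of methoxy on an aromatic carbon. For the measured compounds named here, the one measured step that bears on this is an at least 3.3-fold lower number from compound 1 to compound 2 (0.52 log units; beyond the scatter), which also brought a methyl onto an aromatic carbon, so a further modest fall is expected. The estimated step is a 2.4-fold lower number from compound 2 to compound 3 (0.38 log units; beyond the scatter). In this assay compound 3 is expected to give 25 h, within an estimated range of 10 h to 60 h.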

Compound 3, half-life: 15 h
Estimate against measurement, compound 3: 1.7-fold (0.22 log units) above, and the stated range covers the measured number.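

Replacing methoxy with methyl on this aromatic carbon gives, in this assay, a 4.0-fold lower number from compound 2 to compound 3 (0.60 log units; beyond the scatter), so the half-life responds to a change at this position as well. Among the compounds shown here, this is the first step with true numbers at both ends. The earlier step rests on the limit of compound 1: the limit of > 200 h in this assay, at which 1 of the 3 values shown sits.

The compounds shown leave open how an ethoxy group, a fluorine or an amine on this carbon would compare. They also leave open whether the same swap at the remaining methoxy group would lower the half-life further.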